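The source may hold more compounds than are shown below. What is called first, only, known or untested is meant among the compounds shown, and "the series" means these compounds.

Values in a physicochemical assay, read by spectrophotometry, with a stated time of 6 min; on this read-out lower numbers stand for stronger inhibition and higher numbers for weaker inhibition:
- Compound 1 `O=C(CCCc1nc2ccccc2c(=O)[nH]1)N/N=C/c1cc(O)c(O)c(O)c1`: 40000000 nM
- Compound 2 `COc1cc(/C=N/NC(=O)CCCc2nc3ccccc3c(=O)[nH]2)ccc1O`: 115000000 nM
- Compound 3 `COc1cc(/C=N/NC(=O)CCCc2nc3ccccc3c(=O)[nH]2)cc(O)c1O`: 50000000 nM

Compound 2 gives the highest of the three numbers, so it is the weakest inhibitor so far. The steps touching it are modest: a 2.9-fold higher number from compound 1 to compound 2 (0.46 log units; beyond the scatter) and a 2.3-fold lower number from compound 2 to compound 3 (0.36 log units; beyond the scatter). Compounds 1 and 3 do not separate: a 1.3-fold higher number from compound 1 to compound 3 (0.10 log units; within the scatter).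

The next entry is compound 4 `O=C(CCCc1nc2ccccc2c(=O)[nH]1)N/N=C/c1ccc([N+](=O)[O-])cc1`, not yet measured. The change is 4-nitrophenyl in place of 4-hydroxy-3-methoxyphenyl on a carbon with a double bond to nitrogen, with 4-nitrophenyl in place of 4-hydroxy-3-methoxyphenyl on a carbon with a double bond to nitrogen. Going by the values given here, no measured step involves 4-nitrophenyl, so the evidence is indirect. The closest guide is compound 3, where hydroxy in place of hydrogen on an aromatic carbon went with a 2.3-fold lower number from compound 2 to compound 3 (0.36 log units; beyond the scatter). Compound 4 has no hydroxy on its ring, so a modest move towards a higher number, meaning weaker inhibition, is expected in this assay. The expected step is a 2.2-fold higher number from compound 2 to compound 4 (0.34 log units; beyond the scatter). For compound 4 the estimate is 250000000 nM, with an expected range of 100000000 nM to 700000000 nM.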

Compound 4, half-maximal inhibitory concentration: 270000000 nM
Compound 4: the middle estimate sits 1.1-fold (0.03 log units) below what was measured, and the stated range covers the measured number.
By their numbers in this assay, from the lowest: compounds 1 and 3 (each within the scatter of the next); then compound 2; then compound 4.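

In this assay, going by these compounds alone, 4-nitrophenyl is the first group at this position with no hydrogen-bond donor, and placing it on the carbon with a double bond to nitrogen in place of 4-hydroxy-3-methoxyphenyl gives a 2.3-fold higher number from compound 2 to compound 4 (0.37 log units; beyond the scatter). Set against 3,4,5-trihydroxyphenyl, the same group gives a 6.8-fold higher number from compound 1 to compound 4 (0.83 log units; beyond the scatter), the largest step in the series so far, so the numbers at this position now span a wider range than the hydroxylated rings alone showed. No measurement available here bears on why the number rises with this change.

The swap removes the hydroxy and methoxy groups and brings in the nitro group in one step, so the compounds shown do not separate these contributions. A plain phenyl ring, or a ring carrying an amine or a carboxylic acid in place of the nitro group, would remain to be compared at this position.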